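Adding One Methyl to Compound 2

A few compounds are considered here, and "the series" means these few. Any claim that something is new, unique, unknown or untested is made for them only; others in the source may bear on it.

- compound 1 `CC/C=C\C/C=C\C/C=C\CCCCCCCc1cc(=O)c2c(O)c(C)c(O)c(C)c2o1`: 6790 nM
- compound 2 `CCCCC/C=C\C/C=C\CCCCCCCc1cc(=O)c2c(O)c(C)c(O)cc2o1`: 16100 nM

In a functional assay on MDA-MB-231 cells (Homo sapiens) for antiproliferative activity, read by MTT assay (on this read-out lower numbers stand for stronger inhibition and higher numbers for weaker inhibition), compound 2 holds the higher of the two numbers at 16100 nM, which makes it the weaker inhibitor. Its gap to compound 1 at 6790 nM lies beyond the scatter.

Compound 3 `CCCCC/C=C\C/C=C\CCCCCCCc1cc(=O)c2c(O)c(C)c(O)c(C)c2o1` keeps the side chain of compound 2 and differs from it by one change: methyl in place of hydrogen on an aromatic carbon. Within the data shown here, no measured pair shows this change alone, since compound 1 differs from compound 2 in its side chain as well. Still, compound 1 carries this methyl and reads 6790 nM, so a modest fall in the number is expected. The expected change is a 1.8-fold lower number from compound 2 to compound 3 (0.25 log units; within the scatter). The estimated value for compound 3 is 9000 nM, with an expected range of 4000 nM to 18000 nM.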

Compound 3, half-maximal inhibitory concentration: 16100 nM
Estimate against measurement, compound 3: 1.8-fold (0.25 log units) below; the measured number falls inside the stated range.
By their numbers in this assay, from the lowest: compound 1; then compounds 2 and 3 (each within the scatter of the next).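

In this assay, among these compounds, methyl in place of hydrogen on this aromatic carbon, para to a hydroxy group, gives no change at the digits printed from compound 2 to compound 3 (within the scatter), so the first clean reading of this change shows no effect on the side chain of compound 2. Among the compounds shown here, with that methyl present on both sides, butyl in place of but-1-en-1-yl on the side chain gives a 2.4-fold higher number from compound 1 to compound 3 (0.37 log units; beyond the scatter), which places the only step beyond the scatter at the side chain and not at the aromatic carbon. Nothing at hand gives a cause for either step. On these data alone, it remains open whether an ethyl, a methoxy group or a chlorine atom on this aromatic carbon would read differently from methyl. As far as these compounds go, it also remains open whether the methyl would be equally silent on the side chain of compound 1, and whether a longer chain would extend the side-chain step.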